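Methoxy to methylsulfonyl: clearance notes on the series

The source may report more compounds than this note shows. Statements on the series, on what has been measured and on what is new or still open speak of the compounds shown alone.

In an ADME assay (liver) for metabolic stability, with Liver microsome (Homo sapiens) as the target, read by LC-MS, using microsomes and NADPH, with a stated time of 5 min, at 37 degrees C (a lower number here means slower removal, a higher number faster removal of the compound), compound 1 `CCn1c([C@@H](C)NS(=O)(=O)c2ccc(Cl)cc2)nc2ccc(OC)cc21` gives > 100 mL.min-1.g-1, which is a limit of the assay and not a number. Going by the values given here, compound 2 `CCn1c([C@@H](C)NS(=O)(=O)c2ccc(Cl)cc2)nc2cc(CO)ccc21`, the only other measured member, gives 88 mL.min-1.g-1 in this assay. Compound 3 `CCn1c([C@@H](C)NS(=O)(=O)c2ccc(Cl)cc2)nc2ccc(S(C)(=O)=O)cc21` carries methylsulfonyl in place of methoxy on an aromatic carbon. Among the compounds with values here, no measured step covers this change, so the expectation rests on the structural change alone. A downward step beyond the usual scatter is expected in this assay, estimated as an at least 2.2-fold lower number from compound 1 to compound 3 (0.34 log units; beyond the scatter). For compound 3 the expected value is 45 mL.min-1.g-1, with an estimated range of 15 mL.min-1.g-1 to 100 mL.min-1.g-1.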

Compound 3, intrinsic clearance in microsomes: < 5 mL.min-1.g-1
Compound 3 was reported as a limit (the forecaster's own chance of this, stated with the estimate: 15%); at least 9.0-fold (0.95 log units) between middle value and limit.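

In this assay, going by these compounds alone, methylsulfonyl in place of methoxy on an aromatic carbon gives an at least 20-fold lower number from compound 1 to compound 3 (1.30 log units; beyond the scatter) and is the first step that can be read. Compound 1 sits at a limit of the assay, not at a number: the limit of > 100 mL.min-1.g-1 in this assay, at which 1 of the 3 values shown sits. Compound 3 also sits at a limit, so the step gives only a bound on the change at this position: the limit of < 5 mL.min-1.g-1 in this assay, at which 1 of the 3 values shown sits.

Going by these compounds, how far the true values of compound 1 and compound 3 lie from these limits remains open. Also open, on these data alone, is whether a nitrile or a carboxylic acid on this aromatic carbon would give a similarly low number.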